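Bicyclic-free dihydropyrimidinone series at A3: compound 4 outlook

The source may hold more compounds than are shown below. What is called first, only, known or untested is meant among the compounds shown, and "the series" means these compounds.

Measured compounds:
compound 1 `CC1=C(C(=O)CC(C)C)C(c2ccsc2)NC(=O)N1` — 14%
compound 2 `CCNC(=O)C1=C(C)NC(=O)NC1c1ccsc1` — 1%
compound 3 `CC1=C(C(=O)NC(C)C)C(c2ccsc2)NC(=O)N1` — 1%

In an assay on membranes from HeLa cells for displacement of a labelled ligand from adenosine receptor A3 (Homo sapiens), read by scintillation counting, with a stated time of 180 min, tested at 1 uM (on this read-out lower numbers stand for less inhibition and higher numbers for more inhibition at the one concentration tested (going by the name of the read-out)), compound 3 gives 1%, level with compound 2 and, at the digits printed, together the lowest of the three numbers; compound 1 stands a number 13 percentage points lower from compound 1 to compound 3 (beyond the scatter). The two amide steps a number 13 percentage points lower from compound 1 to compound 2 (beyond the scatter) and a number 13 percentage points lower from compound 1 to compound 3 (beyond the scatter) are modest but beyond the scatter, while no change at the digits printed from compound 2 to compound 3 (within the scatter).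

Compound 4 `CC1=C(c2ncc(C)o2)C(c2ccsc2)NC(=O)N1` carries 5-methyl-1,3-oxazol-2-yl in place of isopropylcarbamoyl on a double-bonded ring carbon. For the measured compounds named here, no measured step exchanges the carbamoyl group for a five-membered aromatic ring, so the two amide steps bear on it only as a reminder that the carbonyl-bearing substituent moves this read-out modestly. From compound 3 a small change is expected, a number 7 percentage points higher from compound 3 to compound 4 (within the scatter), likely within or just beyond the scatter. Compound 4 is estimated at 8%, range -5% to 25%.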

Compound 4, a percentage reported as inhibition, at one concentration (the size of the read-out at that concentration, not a potency): 2%
Compound 4: the middle estimate sits 6 percentage points above what was measured; the measured number falls inside the stated range.
By their numbers in this assay, from the lowest: compounds 2, 3 and 4 (each within the scatter of the next); then compound 1.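

In this assay, replacing either carbamoyl group with 5-methyl-1,3-oxazol-2-yl on the double-bonded ring carbon gives a number 1 percentage points higher from compound 3 to compound 4 (within the scatter) and a number 1 percentage points higher from compound 2 to compound 4 (within the scatter), so an aromatic ring without the amide hydrogen reads level with the amides at this position. The step of a number 12 percentage points lower from compound 1 to compound 4 (beyond the scatter) places this ring with the amides, leaving the isobutylcarbonyl of compound 1 apart from all three. No measurement available here accounts for these numbers.

Open, as far as these compounds go, is whether an ethyl ester or an aminomethyl group at this position would exceed compound 1. Also open, from the compounds shown here alone, is whether the oxazole result holds with a phenyl group in place of thiophen-3-yl.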